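A few compounds are considered here, and "the series" means these few. Any claim that something is new, unique, unknown or untested is made for them only; others in the source may bear on it.

Compound 2 `COc1cc(Cl)cc(-c2nn(-c3cccc(NC(=O)Nc4ccc(Cl)c(Cl)c4)c3)cc2-c2ccncc2)c1` is read in a functional assay on OVCAR-3 cells (Homo sapiens) for inhibition, read by sulforhodamine B assay, with a stated time of 48 h, tested at 0.1 uM (on this read-out lower numbers stand for a stronger effect and higher numbers for a weaker effect at the one concentration tested), where compound 2 gives 101%. Among the compounds with values here, its only measured neighbour is compound 1 `O=C(Nc1cccc(-n2cc(-c3ccncc3)c(-c3cc(O)cc(Cl)c3)n2)c1)Nc1ccc(Cl)c(Cl)c1`, which in this assay gives 101%. The step of no change at the digits printed from compound 1 to compound 2 (within the scatter) came with methyl in place of hydrogen on an oxygen on an aromatic ring. Compound 2 therefore stands level with compound 1, and both sit at a read-out that means essentially no effect at the one concentration tested.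

Compound 3 `COc1cc(Cl)cc(-c2nn(-c3cccc(NC(=O)c4cccc(C(F)(F)F)c4)c3)cc2-c2ccncc2)c1` has not yet been measured. It differs from compound 2 by 3-(trifluoromethyl)phenyl in place of (3,4-dichlorophenyl)amino on a carbonyl carbon. Within the data shown here, no measured pair differs in this way: the one measured step concerns only the methyl on the oxygen on an aromatic ring, so nothing measured bears directly on the change to compound 3. With both measured compounds showing no inhibition, there is no trend to extend, and the estimate for compound 3 is 98%, expected to fall between 80% and 110%. Among the measured compounds shown here, the expected step of a number 3 percentage points lower from compound 2 to compound 3 (within the scatter) is thus none beyond the scatter, though this rests on no measured precedent.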

Compound 3, a percentage reported as activity, at one concentration (the size of the read-out at that concentration, not a potency): 108%
The estimate for compound 3 lay 10 percentage points below the measured number; the measured number falls inside the stated range.
By their numbers in this assay, from the lowest: compounds 1, 2 and 3 (each within the scatter of the next).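

In this assay, putting 3-(trifluoromethyl)phenyl in place of (3,4-dichlorophenyl)amino on the carbonyl carbon gives a number 7 percentage points higher from compound 2 to compound 3 (within the scatter), so this read-out does not separate the two compounds. The change is a sizeable one: the whole aromatic end group is exchanged, and the count of hydrogen-bond donors in that group goes from 1 to 0, yet no inhibition appears at the one concentration tested, so this first look at this position, beyond the earlier change on the oxygen, shows no effect on the read-out from either group. No measurement here offers an explanation for this flat result.

Since all three compounds sit at a level that means essentially no effect, the assay at this concentration cannot show whether this position matters at all, and a difference between the two groups could still appear at higher concentrations. As far as these compounds go, it also remains open whether a quite different group on the same carbonyl carbon, such as a piperidine, a carboxylic acid-bearing phenyl or a short alkyl chain, would bring any inhibition.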